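A side-chain exchange near the limit of measurement

The source may hold more compounds than are shown below. What is called first, only, known or untested is meant among the compounds shown, and "the series" means these compounds.

Measured in a functional assay on MCF7 cells (Homo sapiens) for antiproliferative activity, read by CCK-8 assay, with a stated time of 48 h; on this read-out lower numbers stand for stronger inhibition and higher numbers for weaker inhibition:
- Compound 1 `CNC(=O)/C=C/CNCCOc1ccc(Oc2c(-c3ccc(F)cc3)sc3cc(O)ccc23)cc1`: 16100 nM
- Compound 2 `O=C(CCCNCCOc1ccc(Oc2c(-c3ccc(F)cc3)sc3cc(O)ccc23)cc1)N1CCC1`: > 25000 nM (a limit, not a number)
- Compound 3 `O=C(/C=C/CN1CC(Oc2ccc(Oc3c(-c4ccc(F)cc4)sc4cc(O)ccc34)cc2)C1)N1CCC1`: > 25000 nM (a limit, not a number)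

Compound 2 gives only a limit, > 25000 nM. Compound 3 also gives only a limit, > 25000 nM. The series therefore sits largely at the limit of > 25000 nM in this assay, at which 2 of the 3 values shown sit. Compound 1 alone gives a number, 16100 nM.

The next compound is compound 4 `C=C(C)C(=O)N1CC(Oc2ccc(Oc3c(-c4ccc(F)cc4)sc4cc(O)ccc34)cc2)C1`, and its difference from compound 2 is this: 1-((1-methylethenyl)carbonyl)azetidin-3-yl in place of 2-((3-((azetidin-1-yl)carbonyl)propyl)amino)ethyl on an oxygen on an aromatic ring. In short, 1-((1-methylethenyl)carbonyl)azetidin-3-yl replaces 2-((3-((azetidin-1-yl)carbonyl)propyl)amino)ethyl on an oxygen on an aromatic ring.

For the measured compounds named here, no measured step makes this exchange. The nearest is an at least 1.5-fold higher number from compound 1 to compound 2 (0.19 log units; that floor lies within the scatter), which concerns the far end of the chain and gives only a floor within the scatter. From compound 2 at > 25000 nM, no step beyond the scatter is therefore expected in this assay, in either direction. The expected change is an at least 1.1-fold lower number from compound 2 to compound 4 (0.05 log units; that floor lies within the scatter). Compound 4 is estimated at 22000 nM, with an expected range from 9000 nM to 50000 nM.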

Compound 4, half-maximal inhibitory concentration: > 25000 nM
Compound 4 gave a limit, no number (the forecaster's own chance of this, stated with the estimate: 55%); middle value at least 1.1-fold (0.05 log units) away from the limit.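

In this assay compound 4 gives only a limit, > 25000 nM as its result, so even the exchange of the whole amino side chain on the aromatic oxygen for 1-((1-methylethenyl)carbonyl)azetidin-3-yl yields no number. For the compounds shown here, the steps to compound 4 from compound 2 and from compound 3 cannot be read, and the one readable step, an at least 1.5-fold higher number from compound 1 to compound 4 (0.19 log units; that floor lies within the scatter), gives only a floor and does not separate the two compounds. A large change at this oxygen thus leaves the picture where it was, and the series now sits still more firmly at one boundary: (the limit of > 25000 nM in this assay, at which 3 of the 4 values shown sit).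

How far any of these compounds lie past that limit stays open. So does whether a longer chain or a basic amine carried on the azetidine nitrogen would return a measurable number.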